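This account rests on a few compounds, and the source may have more. Where it says the series, first, only, none or still open, it means among the compounds named here.

The three measured compounds share one core and differ only in the group on a saturated ring carbon. In a functional assay on RH7777 cells (Homo sapiens) for antiproliferative activity against RH7777 (Rattus norvegicus), read by sulforhodamine B assay (a higher number here means a weaker inhibitor, a lower number a stronger inhibitor), compound 2, `CCCCCCCCCCCCCCCCCCNC(=O)[C@H]1CSC(c2cccnc2)N1`, gives 10500 nM. Among the compounds with values here, that is the only number among the three values shown; the other two are limits. Compound 1, `CCCCCCCCCCCCCCCCCCNC(=O)[C@H]1CSC(C2CCCCC2)N1`, reaches only a limit in this assay, > 20000 nM. Compound 3, `CCCCCCCCCCCCCCCCCCNC(=O)[C@H]1CSC(c2ccc(N(C)C)cc2)N1`, likewise reaches only a limit in this assay, > 20000 nM. Both sit at the limit of > 20000 nM in this assay, at which 2 of the 3 values shown sit. The steps of an at least 1.9-fold lower number from compound 1 to compound 2 (0.27 log units; that floor lies within the scatter) and an at least 1.9-fold higher number from compound 2 to compound 3 (0.27 log units; that floor lies within the scatter) therefore run through that limit, and the step that the two limits leave unreadable from compound 1 to compound 3. Compound 4, `CCCCCCCCCCCCCCCCCCNC(=O)[C@H]1CSC(c2ccc(C#N)cc2)N1`, has not yet been measured in this assay. It differs from compound 2 in one place: 4-cyanophenyl in place of pyridin-3-yl on a saturated ring carbon. Within the data shown here, the one measured step that bears on this change, pyridin-3-yl giving way to another six-membered aromatic ring of carbon only, is an at least 1.9-fold higher number from compound 2 to compound 3 (0.27 log units; that floor lies within the scatter), which ended at the limit; a higher number beyond the scatter is therefore expected, and a limit is about as likely as a number. The estimate for compound 4 in this assay is 18000 nM, within a range from 8000 nM to 40000 nM. The expected step is a 1.7-fold higher number from compound 2 to compound 4 (0.23 log units; within the scatter).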

Compound 4, half-maximal inhibitory concentration: > 20000 nM
Compound 4: only a limit was reported; the forecaster's own chance of this, stated with the estimate: 50%; middle value at least 1.1-fold (0.04 log units) from the limit.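

In this assay, from the compounds shown here alone, 4-cyanophenyl in place of pyridin-3-yl gives an at least 1.9-fold higher number from compound 2 to compound 4 (0.27 log units; that floor lies within the scatter), so the true size of this step remains unknown. The steps from compound 3 to compound 4 and from compound 1 to compound 4 cannot be read, so nitrile and dimethylamino on the aromatic ring cannot be ranked here, nor can 4-cyanophenyl and cyclohexyl. A second group on a six-membered aromatic ring of carbon only thus also ends at a limit, leaving compound 2 the only one of the four with a number: the limit of > 20000 nM in this assay, at which 3 of the 4 values shown sit.

The compounds shown leave open whether a plain phenyl group or a pyridin-4-yl group would give a number in this assay. They also leave open how far compound 2 truly stands from the other three.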